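Two Aryl Swaps on an Imidazole Agonist Series

The source may report more compounds than this note shows. Statements on the series, on what has been measured and on what is new or still open speak of the compounds shown alone.

Measured compounds:
compound 1, `N#Cc1ccc(Cc2cnc(CCc3ccc(-c4ccccc4C(=O)O)cc3)[nH]2)cc1`, 5890 nM
compound 2, `CCCCc1cnc(C(CCCO)Cc2ccc(-c3ccccc3C(=O)O)cc2)[nH]1`, 1900 nM

The two compounds were tested in an in vitro functional assay on cells for agonist activity at Bombesin receptor subtype-3 (Homo sapiens), read by luminescence and calcium flux; on this read-out lower numbers stand for an effect already at smaller amounts and higher numbers for an effect only at larger amounts of compound. In this assay compound 1 gives 5890 nM, the higher of the two numbers shown, while compound 2 gives 1900 nM, a gap that lies beyond the usual scatter. No single-point comparison between them is available, and their structures differ in more than one place.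

Compound 3, `O=C(O)c1ccccc1-c1ccc(CCc2ncc(Cc3cccc(F)c3F)[nH]2)cc1`, has not been measured. It differs from compound 1 as follows: 2,3-difluorophenyl in place of 4-cyanophenyl on a saturated chain carbon bound to an aromatic carbon. Within the data shown here, nothing among the measured compounds tests this change directly, so the expectation rests on the value of compound 1 alone. A step of modest size is expected, a 1.5-fold lower number from compound 1 to compound 3 (0.17 log units; within the scatter), plausibly toward a lower number but not clearly beyond the scatter. Compound 3 is therefore estimated at 4000 nM, within a range from 1300 nM to 12000 nM.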

Compound 3, half-maximal effective concentration: 87 nM
Estimate against measurement, compound 3: 46-fold (1.66 log units) above, and the stated range ends above it.
By their numbers in this assay, from the lowest: compound 3; then compound 2; then compound 1.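

In this assay, among these compounds, the group on a saturated chain carbon bound to an aromatic carbon proves decisive: 2,3-difluorophenyl in place of 4-cyanophenyl gives a 68-fold lower number from compound 1 to compound 3 (1.83 log units; beyond the scatter) in the first comparison here that changes one place only. The earlier compounds shown here, which differ in more than one place, could not isolate this position. The size of the step appears even though both groups hold 8 heavy atoms and one six-membered aromatic ring of carbon only.

No measurement at hand accounts for the step or separates the departure of the nitrile from the arrival of the two fluorines. On these data alone, whether a plain phenyl, a single fluorine or 2,3-dichlorophenyl at this place would keep the low number remains open, as does whether the exchange would carry over to the core of compound 2.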